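The source may hold more compounds than are shown below. What is called first, only, known or untested is meant among the compounds shown, and "the series" means these compounds.

Measured compounds:
compound 1, `C#CCOc1ccc(/C=C/C(=O)c2ccc([N+](=O)[O-])cc2)cc1`, 44%
compound 2, `O=C(/C=C/c1ccc(OCc2cn(Cc3cccc(Br)c3)nn2)cc1)c1ccc(Br)cc1`, 36%
compound 3, `COc1ccc(C(=O)/C=C/c2ccc(OCc3cn(Cc4cccc(Br)c4)nn3)cc2)cc1`, 45%

All three were run in a functional assay on MCF7 cells (Homo sapiens) for inhibition, read by MTT assay, with a stated time of 48 h, tested at 10 uM; on this read-out lower numbers stand for less inhibition of growth and higher numbers for more inhibition of growth at the one concentration tested. Compound 3 carries the highest of the three numbers shown, but the gap to compound 1 and the gap to compound 2 are both within the scatter, so no ranking among the three can be read from these numbers. For the measured compounds named here, the one measured step that connects two of them, a number 9 percentage points higher from compound 2 to compound 3 (within the scatter), is a change on the ring that carries the carbonyl and stays within the scatter.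

Compound 4, `COc1ccc(C(=O)/C=C/c2ccc(OCc3cn(Cc4cccc(F)c4)nn3)cc2)cc1`, is the next member. It differs from compound 3 by fluoro in place of bromo on an aromatic carbon. Going by the values given here, no measured pair exchanges bromo for fluoro anywhere, so nothing bears directly on this change; the only step on record, the one from compound 2 to compound 3, concerns a different ring and was itself within the scatter. The numbers across the series are narrow, and nothing suggests a sensitivity to the substituent on the benzyl ring of the triazole. The step expected in this assay is therefore none beyond the scatter, and the estimated step is a number 1 percentage points lower from compound 3 to compound 4 (within the scatter). Compound 4 is accordingly expected to give 44%, with a range from 30% to 58%.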

Compound 4, percent growth inhibition at one concentration: 41%
For compound 4 the middle estimate is 3 percentage points above the measured one, and the stated range covers the measured number.
By their numbers in this assay, from the lowest: compounds 2, 4, 1 and 3 (each within the scatter of the next).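

In this assay, for the compounds shown here, the exchange of 3-bromobenzyl for 3-fluorobenzyl gives a number 4 percentage points lower from compound 3 to compound 4 (within the scatter), the first measured step on this ring of the series, and it stays within the scatter. Bromo and fluoro on an aromatic carbon, meta to a large group, are therefore not told apart by this read-out at the one concentration tested, and neither this step nor the earlier one on the ring that carries the carbonyl, a number 9 percentage points higher from compound 2 to compound 3 (within the scatter), can be read as a real change. No measurement at hand addresses the molecular basis of this result.

Whether any group at this position can move the number beyond the scatter stays open, since an amine, a carboxylic acid or a longer chain in place of the fluoro lies outside the compounds shown. Going by these compounds alone, with only one concentration per compound, it also stays open whether compound 3 and compound 4 would separate at other concentrations in this assay.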